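The source may hold more compounds than are shown below. What is called first, only, known or untested is meant among the compounds shown, and "the series" means these compounds.

Compound 3 `C[C@@H](O[C@@H]1CN(C(=O)NC(C)(C)C)C[C@H]1c1ccc(F)cc1)c1cc(C(F)(F)F)cc(C(F)(F)F)c1` gives the lowest number of the three compounds measured in an assay on CHO cells for displacement of a labelled ligand from Substance-P receptor (Homo sapiens) (on this read-out higher numbers stand for weaker inhibition and lower numbers for stronger inhibition), at 0.14 nM. Compound 1 `C[C@@H](O[C@@H]1CN(C(=O)[C@@H]2COC(=O)N2)C[C@H]1c1ccc(F)cc1)c1cc(C(F)(F)F)cc(C(F)(F)F)c1` gives 0.34 nM, and compound 2 `C[C@@H](O[C@@H]1CN(C(=O)N(C)C)C[C@H]1c1ccc(F)cc1)c1cc(C(F)(F)F)cc(C(F)(F)F)c1` gives 0.38 nM. The step of a 2.4-fold lower number from compound 1 to compound 3 (0.39 log units; beyond the scatter) and the step of a 2.7-fold lower number from compound 2 to compound 3 (0.43 log units; beyond the scatter) are both modest, while the step of a 1.1-fold higher number from compound 1 to compound 2 (0.05 log units; within the scatter) lies within the scatter.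

Compound 4 `C[C@@H](O[C@@H]1CN(C2=CC(=O)OC2)C[C@H]1c1ccc(F)cc1)c1cc(C(F)(F)F)cc(C(F)(F)F)c1` differs from compound 3 by a group of 6 heavy atoms (4 carbon, 2 oxygen; one five-membered non-aromatic ring with 1 hetero atom) in place of a group of 7 heavy atoms (5 carbon, 1 nitrogen, 1 oxygen; no ring), on an amine nitrogen in a ring. Going by the values given here, every measured step so far swaps one substituent on a carbonyl carbon for another, keeping the carbonyl on the ring nitrogen; in compound 4 that carbonyl is gone and a ring is attached directly. Among the compounds with values here, no measured pair shows such a change, so the three modest steps give only a sense of scale, not direction. The narrow spread across compounds 1, 2 and 3 suggests the shared core tolerates varied groups here, and a modest weakening is expected for compound 4, a 4.3-fold higher number from compound 3 to compound 4 (0.63 log units; beyond the scatter). Compound 4 is therefore estimated at 0.6 nM, with a range from 0.12 nM to 3 nM.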

Compound 4, half-maximal inhibitory concentration: 0.16 nM
For compound 4 the middle estimate is 3.8-fold (0.57 log units) above the measured one, and the stated range covers the measured number.
By their numbers in this assay, from the lowest: compounds 3 and 4 (each within the scatter of the next); then compounds 1 and 2 (each within the scatter of the next).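

In this assay the ring nitrogen does not need a carbonyl attached to it: placing the five-membered ring directly on that nitrogen gives a 1.1-fold higher number from compound 3 to compound 4 (0.06 log units; within the scatter) and also removes the hydrogen-bond donor of the (tert-butyl)carbamoyl group. The position therefore accepts more than substituted carbonyl groups, and the same ring gives a 2.4-fold lower number from compound 2 to compound 4 (0.38 log units; beyond the scatter) and a 2.1-fold lower number from compound 1 to compound 4 (0.33 log units; beyond the scatter) as modest steps in the same direction. No measurement at hand explains why such different groups give such close numbers.

Only one group of this directly attached kind is shown, so it remains open whether the low number depends on that ring's own carbonyl or double bonds. Also open, on these data alone, is how a simple amine, a carboxylic acid or a longer chain would behave on this nitrogen.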